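A few compounds are considered here, and "the series" means these few. Any claim that something is new, unique, unknown or untested is made for them only; others in the source may bear on it.

Measured compounds in this set:

compound 1, `COC(=O)c1cc(-n2cc(-c3cc(OC)cc(OC)c3)nn2)ccc1O`, giving 3% in a functional assay on CCRF-CEM cells (Homo sapiens) for inhibition, read by MTT assay, with a stated time of 2 days, tested at 10 uM; on this read-out higher numbers stand for more inhibition at the one concentration tested (going by the name of the read-out) and lower numbers for less inhibition
compound 2, `COc1cc(OC)cc(-c2cn(-c3ccc(O)c(C(=O)O)c3)nn2)c1`, giving 9%
compound 3, `COC(=O)c1cc(-n2cc(-c3cccc(O)c3)nn2)ccc1O`, giving 5%

The change from compound 1 to compound 2 is hydrogen in place of methyl on an oxygen next to a carbonyl group. The step it made is a number 6 percentage points higher from compound 1 to compound 2 (within the scatter). The values of compound 1, compound 2 and compound 3 all lie within the usual scatter of one another, so no order among them can be read from this assay.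

Compound 4, `O=C(O)c1cc(-n2cc(-c3cccc(O)c3)nn2)ccc1O`, has not yet been measured. It stands to compound 3 as compound 2 stands to compound 1: the change is hydrogen in place of methyl on an oxygen next to a carbonyl group, at a place described in the same words as for the earlier pair, so it is the same change. The difference between the two cores is not broken down here.

For compound 4 the expected step is a number 5 percentage points higher from compound 3 to compound 4 (within the scatter), resting on the earlier step of a number 6 percentage points higher from compound 1 to compound 2 (within the scatter), which stayed within the scatter. Compound 4 is therefore estimated at 10%, with a range from -5% to 25% expected.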

Compound 4, a percentage reported as inhibition, at one concentration (the size of the read-out at that concentration, not a potency): 3%
Estimate against measurement, compound 4: 7 percentage points above; measured number inside the range.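

In this assay the change from methoxycarbonyl to carboxy gives a number 2 percentage points lower from compound 3 to compound 4 (within the scatter) on this core. Set beside the same change on the core of compound 1, the two steps do not differ: the same change on two cores in this assay, a number 6 percentage points higher (within the scatter) from compound 1 to compound 2 and a number 2 percentage points lower (within the scatter) from compound 3 to compound 4, 8 percentage points apart, within the scatter of two such steps
This shows that the change stayed within the scatter on both cores, with all numbers low; it does not show that the change has a real effect that carries from one core to another, and no direction can be read from the two steps.

The compounds shown vary only between methoxycarbonyl and carboxy at this place and between methoxy and hydroxy on the other aromatic ring, so what an amide or an amine at the place of the methoxycarbonyl group would give remains open. Also open, on these data alone, is whether the change would give a readable step on a core whose inhibition lies clearly beyond the scatter of these four compounds.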